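The source may hold more compounds than are shown below. What is called first, only, known or untested is meant among the compounds shown, and "the series" means these compounds.

Notes on the series. Compound 2 `COc1cc(-c2cc(C(=O)O)c3ccccc3n2)ccc1OCC(=O)Nc1ccc(F)cc1` gives 286000 nM in an ADME assay on HaCaT cells (Homo sapiens) for inhibition; a lower number here means a stronger inhibitor, a higher number a weaker inhibitor; compound 1 `COc1cc(-c2cc(C(=O)O)c3ccccc3n2)ccc1OCC(=O)Nc1cccc(F)c1` gives 148000 nM in this assay, and the step of a 1.9-fold higher number from compound 1 to compound 2 (0.29 log units; within the scatter) separates the pair. Compound 3 `COc1cc(-c2cc(C(=O)O)c3ccccc3n2)ccc1OCC(=O)Nc1cccc(C(F)(F)F)c1` differs from compound 2 by 3-(trifluoromethyl)phenyl in place of 4-fluorophenyl on an amide-type nitrogen. The step of a 1.9-fold higher number from compound 1 to compound 2 (0.29 log units; within the scatter) is the only one measured so far; it also exchanges the ring on the amide-type nitrogen and stayed within the scatter. The step of a 1.1-fold lower number from compound 2 to compound 3 (0.06 log units; within the scatter) is therefore expected to stay within the scatter as well. Compound 3 is estimated at 250000 nM in this assay, with a range from 100000 nM to 600000 nM.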

Compound 3, half-maximal inhibitory concentration: 160000 nM
For compound 3 the middle estimate is 1.6-fold (0.19 log units) above the measured one; the range from low to high includes it.
By their numbers in this assay, from the lowest: compounds 1, 3 and 2 (each within the scatter of the next).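

Working notes: in this assay, the ring on the amide-type nitrogen accepts 3-(trifluoromethyl)phenyl, with 10 heavy atoms against 7 in 4-fluorophenyl, without a change beyond the scatter (a 1.8-fold lower number from compound 2 to compound 3 (0.25 log units; within the scatter)). Trifluoromethyl in place of fluoro on an aromatic carbon gives the first step that exchanges only this substituent, and it also stays within the scatter (a 1.1-fold higher number from compound 1 to compound 3 (0.03 log units; within the scatter)). No supporting evidence bears on these results.

From the compounds shown here alone, whether an amine or a carboxylic acid on this ring would move the number beyond the scatter stays open. The same question stands for a longer chain in place of the ring on the amide-type nitrogen.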